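Thiocarbamate replaces allyl carbamate on the ribose hydroxymethyl oxygen

This account rests on a few compounds, and the source may have more. Where it says the series, first, only, none or still open, it means among the compounds named here.

Measured so far:
Compound 1 `C/N=C(\S)OC[C@H]1OC(n2cnc3c(NC4CCOC4)ncnc32)[C@H](O)[C@@H]1O` gives 45 nM in an assay on DDT1 cells (Cricetulus griseus) for binding affinity to adenosine receptor A1 (Homo sapiens), read by radioligand binding; a higher number here means a weaker inhibitor, a lower number a stronger inhibitor.
Compound 2 `C=CCNC(=O)OC[C@H]1OC(n2cnc3c(NC4CCOC4)ncnc32)[C@H](O)[C@@H]1O` gives 524 nM in this assay.

Compound 2 stands with the highest of the two numbers in this assay; its nearest neighbour is compound 1, and the step of a 12-fold higher number from compound 1 to compound 2 (1.07 log units; beyond the scatter) lies beyond the scatter. Compound 3 `CN(C)C(=S)OC[C@H]1OC(n2cnc3c(NC4CCOC4)ncnc32)[C@H](O)[C@@H]1O` differs from compound 2 by a group of 5 heavy atoms (3 carbon, 1 nitrogen, 1 sulfur; no ring) in place of a group of 6 heavy atoms (4 carbon, 1 nitrogen, 1 oxygen; no ring), on an oxygen on a saturated carbon. Going by the values given here, the only measured step that bears on this change is a 12-fold higher number from compound 1 to compound 2 (1.07 log units; beyond the scatter), a large step, and it ran from a sulfur-containing group to the allylcarbamoyl group. Since the group entering compound 3 again contains sulfur and no hydrogen-bond donor, compound 3 is expected to lie closer to compound 1 than to compound 2, with the step of a 6.6-fold lower number from compound 2 to compound 3 (0.82 log units; beyond the scatter) expected to be a lower number. Compound 3 is estimated at 80 nM, within a range from 20 nM to 320 nM.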

Compound 3, inhibition constant: 205 nM
The estimate for compound 3 lay 2.6-fold (0.41 log units) below the measured number, within the range that was stated.
By their numbers in this assay, from the lowest: compound 1; then compound 3; then compound 2.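

In this assay, the group on this oxygen on a saturated carbon now has a third form, and it falls in the middle: the change gives a 2.6-fold lower number from compound 2 to compound 3 (0.41 log units; beyond the scatter), yet there is still a 4.6-fold higher number from compound 1 to compound 3 (0.66 log units; beyond the scatter). Compounds 1 and 3 both carry sulfur in this group, and both steps are printed as beyond the scatter, so among these compounds sulfur alone does not set the number. Nothing measured here accounts for the differences among the three groups.

On these data alone, the allylcarbamoyl group and the group in compound 3 differ in more than sulfur, so what the sulfur contributes remains open; a dimethylcarbamoyl or an allylthiocarbamoyl group would bear directly on that. As far as these compounds go, how a longer chain, an amine or a carboxylic acid on this oxygen would read also remains open.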